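A Smaller Group on the Ring Nitrogen

The compounds below may be only part of what the source reports. "The series", "measured", "known", "first", "only" and "open" are said of these compounds alone.

Of the compounds shown here, three have so far been measured in an assay on isolated protein for displacement of a labelled ligand from growth hormone secretagogue receptor type 1 (Homo sapiens), with a stated time of 1 h; a higher number here means a weaker inhibitor, a lower number a stronger inhibitor. Compound 1 `CC(C)(N)C(=O)N[C@H](COCc1ccccc1)c1nnnn1Cc1ccc(NS(C)(=O)=O)cc1` gives only a limit in this assay, > 5000 nM. Compound 2 `CN(c1ccccc1CCCn1nnnc1[C@@H](COCc1ccccc1)NC(=O)C(C)(C)N)S(C)(=O)=O` gives 1720 nM in this assay. Compound 3 `COC(=O)C(c1ccccc1)n1nnnc1[C@@H](COCc1ccccc1)NC(=O)C(C)(C)N` gives 470 nM in this assay, the lowest of the two numbers, with compound 2 sitting above it by more than the scatter. The remaining value is that of compound 1, which sits at the limit of > 5000 nM in this assay, at which 1 of the 3 values shown sits.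

Compound 4 `CC(C)(N)C(=O)N[C@H](COCc1ccccc1)c1nnnn1CC#N` has not yet been measured. It differs from compound 3 by cyanomethyl in place of methoxycarbonyl)(benzyl on an aromatic nitrogen. No measured pair isolates this change, so the size of the step cannot be read from the numbers shown. Since compound 3 carries the largest group at that position among the compounds measured and gives the lowest number, the expected step is a 6.4-fold higher number from compound 3 to compound 4 (0.81 log units; beyond the scatter), upward and beyond the scatter. Compound 4 is therefore estimated at 3000 nM, within a range from 800 nM to 10000 nM.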

Compound 4, inhibition constant: 4170 nM
For compound 4 the middle estimate is 1.4-fold (0.14 log units) below the measured one; the range from low to high includes it.
By their numbers in this assay, from the lowest: compound 3; then compound 2; then compound 4. At a limit, above all of these: compound 1.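

In this assay, within the data shown here, cyanomethyl in place of methoxycarbonyl)(benzyl on an aromatic nitrogen gives an 8.9-fold higher number from compound 3 to compound 4 (0.95 log units; beyond the scatter), the first step at this position with a readable size. The change takes away 11 heavy atoms, including a six-membered aromatic ring, and puts in 3 heavy atoms with no ring, and compound 4 ends up with a clearly higher number than compound 3. The other step, an at least 1.1-fold lower number from compound 1 to compound 4 (0.07 log units; that floor lies within the scatter), is only a floor set by a limit, which compound 1 holds: the limit of > 5000 nM in this assay, at which 1 of the 4 values shown sits.

The step removes the methoxycarbonyl and the phenyl ring together, so it leaves open which of them matters at this position. A plain benzyl, or a carboxylic acid or an amine in place of the methoxycarbonyl, on the same aromatic nitrogen would separate the two.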